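This account rests on a few compounds, and the source may have more. Where it says the series, first, only, none or still open, it means among the compounds named here.

Going by the values given here, in a functional assay on HT-29 cells (Homo sapiens) for antiproliferative activity, read by sulforhodamine B assay, with a stated time of 48 h (on this read-out lower numbers stand for stronger inhibition and higher numbers for weaker inhibition), compound 2 `O=C1NCCN1c1ccc(S(=O)(=O)Nc2ccc(OC(F)F)cc2)cc1` gives 650 nM, the only actual number available so far. Compound 1 `O=C1NCCN1c1ccc(S(=O)(=O)Nc2ccc(C3CCCCC3)cc2)cc1` is recorded only as a limit, > 1000 nM. Among the compounds with values here, the one measured step at this position is an at least 1.5-fold lower number from compound 1 to compound 2 (0.18 log units; that floor lies within the scatter), and its floor lies within the scatter, so it shows no firm gain and gives no firm size for a change here. Compound 3 `O=C1NCCN1c1ccc(S(=O)(=O)Nc2ccc(Br)cc2)cc1` carries bromo in place of difluoromethoxy on an aromatic carbon, para to a large group: bromo in place of difluoromethoxy on an aromatic carbon. Within the data shown here, no measured step covers bromo, so the expectation rests on compound 2 at 650 nM as the sole anchor, and no direction can be argued. The expected step, no change at the digits printed from compound 2 to compound 3 (within the scatter), is estimated to stay within the scatter. Compound 3 is estimated at 650 nM, with an expected range from 250 nM to 1700 nM.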

Compound 3, half-maximal inhibitory concentration: 300 nM
Beside the measured number, compound 3's estimate is 2.2-fold (0.34 log units) above it; measured number inside the range.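

In this assay this position now gives a step that clears the scatter, a 2.2-fold lower number from compound 2 to compound 3 (0.34 log units; beyond the scatter), whereas the earlier step gave no firm gain. Bromo also gives a firm gain over cyclohexyl, an at least 3.3-fold lower number from compound 1 to compound 3 (0.52 log units; beyond the scatter), so among the three groups shown on this aromatic carbon, bromo gives the lowest number. Compound 1 is recorded only as a limit, so this second step is a floor and its full size stays unknown: the limit of > 1000 nM in this assay, at which 1 of the 3 values shown sits.

The compounds shown do not say why bromo gives the lower number, or whether the gain is particular to bromine or would also appear with chloro, fluoro or methyl at this place. As far as these compounds go, how an amine or a carboxylic acid would behave on the same aromatic carbon also remains open.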